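The source may report more compounds than this note shows. Statements on the series, on what has been measured and on what is new or still open speak of the compounds shown alone.

The measured compounds:

compound 1 `COc1ccc(C2=C(c3cc(OC)c(OC)c(OC)c3)C(=O)C(OC(C)=O)C2)cc1` — > 100 ug/mL
compound 2 `COc1ccc(C2=C(c3cc(OC)c(OC)c(OC)c3)C(=O)C(O[SiH2]C(C)(C)C)C2)cc1` — 28 ug/mL

In an ADME assay on DU-145 cells (Homo sapiens) for cytotoxicity, read by MTT assay, with a stated time of 72 h (a higher number here means a weaker inhibitor, a lower number a stronger inhibitor), compound 1 gives > 100 ug/mL, which is a limit of the assay and not a number. Compound 1 therefore stands at the limit of > 100 ug/mL in this assay, at which 1 of the 2 values shown sits. Among the compounds with values here, compound 2 gives 28 ug/mL in this assay, and the one measured step, an at least 3.5-fold lower number from compound 1 to compound 2 (0.55 log units; beyond the scatter), concerns the group on the oxygen on the saturated carbon and nothing else.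

Compound 3 `COc1ccc(C2=C(c3cc(OC)c(OC)c(OC)c3)C(=O)C(OC(C)=O)C2)cc1O` differs from compound 1 by hydroxy in place of hydrogen on an aromatic carbon, the 4-methoxyphenyl becoming 3-hydroxy-4-methoxyphenyl. Within the data shown here, the step from compound 1 to compound 2 does not touch this part of the shared core, so no measured step bears on the change. With only a limit known for compound 1, the step is expected to be an at least 1.6-fold lower number from compound 1 to compound 3 (0.22 log units; that floor lies within the scatter), with no firm direction. Compound 3 is estimated at 60 ug/mL in this assay, in a range from 10 ug/mL to 150 ug/mL.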

Compound 3, half-maximal inhibitory concentration: > 100 ug/mL
Compound 3: a limit, no number (the forecaster's own chance of this, stated with the estimate: 45%); middle value at least 1.6-fold (0.22 log units) from the limit.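

In this assay compound 3 gives > 100 ug/mL, which is a limit of the assay and not a number. Compound 1 stands at a limit too, so no step between compound 1 and compound 3 can be read: the limit of > 100 ug/mL in this assay, at which 2 of the 3 values shown sit.

The compounds shown leave open whether hydroxy in place of hydrogen on an aromatic carbon changes the value at all.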